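This account rests on a few compounds, and the source may have more. Where it says the series, first, only, none or still open, it means among the compounds named here.

Series notes. Among the measured compounds shown here, in a functional assay on NCI-H460 cells (Homo sapiens) for inhibition, read by sulforhodamine B assay, with a stated time of 48 h, tested at 1 uM (a lower number here means a stronger effect, a higher number a weaker effect of the compound at the concentration tested), compound 3 `COc1cc(Cl)cc(-c2nn(-c3cccc(NC(=O)Nc4ccc(Cl)c(Cl)c4)c3)cc2-c2ccncc2)c1` gives 77%, the highest of the three numbers so far. For the measured compounds named here, compound 1 `O=C(Nc1cccc(-n2cc(-c3ccncc3)c(-c3cc(O)cc(Cl)c3)n2)c1)Nc1ccc(Cl)c(Cl)c1` gives 58%; the one recorded single-place step, a number 19 percentage points higher from compound 1 to compound 3 (beyond the scatter), is modest but beyond the scatter. Compound 2 `COc1cc(Cl)cc(-c2nn(-c3cccc(NC(=O)Nc4cc(C(F)(F)F)cc(C(F)(F)F)c4)c3)cc2-c2ccncc2)c1`, carrying a different distal aryl group on the urea, gives 13%, far apart from compound 3. Compound 4 `COc1cc(Cl)cc(-c2nn(-c3cccc(NC(=O)c4cccc(C(F)(F)F)c4)c3)cc2-c2ccncc2)c1` differs from compound 3 by 3-(trifluoromethyl)phenyl in place of (3,4-dichlorophenyl)amino on a carbonyl carbon. Going by the values given here, no measured step covers this change; the only guidance is that compound 2 and compound 3 show the distal aryl portion shifts the read-out widely. A step in either direction is therefore possible for compound 4, and the estimate is set near the middle of the observed range, expected as a number 27 percentage points lower from compound 3 to compound 4 (beyond the scatter), giving an estimated 50% between 15% and 90%.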

Compound 4, a percentage reported as activity, at one concentration (the size of the read-out at that concentration, not a potency): 93%
The estimate for compound 4 lay 43 percentage points below the measured number, outside the stated range (above it).
By their numbers in this assay, from the lowest: compound 2; then compound 1; then compound 3; then compound 4.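

In this assay the change from (3,4-dichlorophenyl)amino to 3-(trifluoromethyl)phenyl on the carbonyl carbon gives a number 16 percentage points higher from compound 3 to compound 4 (beyond the scatter), so this swap weakens the effect at the concentration tested. It replaces the hydrogen-bond donor and the aryl substitution together, so the step cannot assign the shift to either one. No supporting data bear on the cause of this step. Still open, from the compounds shown here alone, is how (3-(trifluoromethyl)phenyl)amino on the same carbonyl carbon would read, since that group would separate the amino nitrogen from the aryl substitution.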